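Furan to Thiophene Swap on a Saturated Ring Carbon

A few compounds are considered here, and "the series" means these few. Any claim that something is new, unique, unknown or untested is made for them only; others in the source may bear on it.

Measured compounds:
- compound 1, `CC1=C(C(=O)OCC(C)C)C(c2ccoc2)NC(=O)N1C`: in an assay on membranes from HeLa cells for displacement of a labelled ligand from adenosine receptor A3 (Homo sapiens), read by scintillation counting, with a stated time of 180 min, tested at 1 uM (a higher number here means more inhibition at the concentration tested (going by the name of the read-out), a lower number less inhibition), compound 1 gives 16%
- compound 2, `CC1=C(C(=O)OCC(C)C)C(c2cccs2)NC(=O)N1C`: in this assay compound 2 gives 5%
- compound 3, `CCNC(=O)C1=C(C)NC(=O)NC1c1ccoc1`: in this assay compound 3 gives 1%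

Compound 1 and compound 2 differ in one place, (thiophen-2-yl in place of furan-3-yl on a saturated ring carbon). This step gave a number 11 percentage points lower from compound 1 to compound 2 (beyond the scatter). Compound 3 carries an ethylcarbamoyl group where compound 1 carries an isobutoxycarbonyl group; the difference between the two cores is not broken down here. Compound 3 stands lowest of the three numbers, within the scatter of compound 2 and beyond it from compound 1.

Compound 4, `CCNC(=O)C1=C(C)NC(=O)NC1c1cccs1`, has not been measured in this assay. It differs from compound 3 by thiophen-2-yl in place of furan-3-yl on a saturated ring carbon. This is the same kind of change as from compound 1 to compound 2, though there the saturated ring carbon sits next to the ring atom that bears an isobutoxycarbonyl group, whereas here it sits next to the ring atom that bears an ethylcarbamoyl group.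

Because compound 3 already gives 1%, little room remains for a drop; the step from compound 3 to compound 4 is expected to be no change at the digits printed from compound 3 to compound 4 (within the scatter), smaller than the earlier one. Compound 4 is expected to give 1%, between -8% and 10%.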

Compound 4, a percentage reported as inhibition, at one concentration (the size of the read-out at that concentration, not a potency): 4%
The estimate for compound 4 lay 3 percentage points below the measured number; measured number inside the range.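

With an ethylcarbamoyl group in place of the isobutoxycarbonyl group, thiophen-2-yl in place of furan-3-yl gave a number 3 percentage points higher from compound 3 to compound 4 (within the scatter) in this assay. Set beside the earlier step, the new one does not differ from it by more than the scatter allows: the same change on two cores in this assay, a number 11 percentage points lower (beyond the scatter) from compound 1 to compound 2 and a number 3 percentage points higher (within the scatter) from compound 3 to compound 4, 14 percentage points apart, within the scatter of two such steps. For the compounds shown here, this gives no sign that the change behaves differently on the two cores, but it does not show that the drop seen on the first core carries over, as the numbers for compound 3 and compound 4 are both small and only two pairs are available.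

The compounds shown leave open how the change would read on a core giving a much larger number in this assay. They also leave open how furan-2-yl and thiophen-3-yl would compare, so the exchange of oxygen for sulfur cannot be separated from the difference in how the ring is attached.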